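Pyrazole amides as mGlu5 negative modulators: a fluorine shift

The source may hold more compounds than are shown below. What is called first, only, known or untested is meant among the compounds shown, and "the series" means these compounds.

Measured so far in a functional assay on HEK293 cells for negative allosteric modulation of metabotropic glutamate receptor 5 (Homo sapiens), read by FLIPR and calcium flux; a higher number here means a weaker inhibitor, a lower number a stronger inhibitor:
Compound 1, `Cc1cccc(NC(=O)c2nn(C)c3c2CCCC3)n1`, gives 27 nM.
Compound 2, `Cc1cccc(NC(=O)c2nn(C)c3ccccc23)n1`, gives > 1000 nM, which is a limit of this assay, not a number.
Compound 3, `Cc1cccc(NC(=O)c2nn(C)c(-c3ccc(F)cc3)c2C)n1`, gives 1.1 nM.

Among the two numbers that are given, compound 3 carries the lowest; compound 1 is the nearest, and the gap between them lies beyond the usual scatter.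

Compound 4, `Cc1cccc(NC(=O)c2nn(C)c(-c3cc(F)cc(F)c3)c2C)n1`, is not yet measured. It differs from compound 3 by 3,5-difluorophenyl in place of 4-fluorophenyl on an aromatic carbon. Going by the values given here, no pair of measured compounds shows what such a change does here, so the step is expected to be small, in either direction, or none beyond the scatter: the step from compound 3 to compound 4 is estimated as a 1.8-fold higher number from compound 3 to compound 4 (0.26 log units; within the scatter). Compound 4 is expected to give 2 nM in this assay, within 0.5 nM to 8 nM.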

Compound 4, half-maximal inhibitory concentration: 5.3 nM
Compound 4: middle estimate off by 2.7-fold (0.42 log units), on the low side; the measured number falls inside the stated range.
By their numbers in this assay, from the lowest: compound 3; then compound 4; then compound 1. At a limit, above all of these: compound 2.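

Going by these compounds alone, the swap of 4-fluorophenyl for 3,5-difluorophenyl gives the first step that can be read at this position on the shared core in this assay: a 4.8-fold higher number from compound 3 to compound 4 (0.68 log units; beyond the scatter). The number at this aromatic carbon therefore responds to how fluorine is set out on the phenyl ring, and the extra fluorine brings no gain here. Nothing measured here accounts for this step.

Still open, from the compounds shown here alone, is whether the count or the placement of fluorine sets the step. Also open, going by these compounds, is how phenyl without fluorine, or phenyl carrying a methoxy group or an amine, would compare at this position.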